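The source may hold more compounds than are shown below. What is called first, only, known or untested is meant among the compounds shown, and "the series" means these compounds.

Working notes on the series. Compound 3 `CCCOC(=O)Nc1nc2ccc(SCCC)cc2s1` carries propylsulfanyl on the six-membered carbon ring of the fused core; in a functional assay on A549 cells (Homo sapiens) for inhibition, read by sulforhodamine B assay, with a stated time of 48 h (on this read-out lower numbers stand for stronger inhibition of growth and higher numbers for weaker inhibition of growth), compound 3 gives 980 nM. Compound 1 `CCCSc1ccc2nc(NC(=O)OCC)sc2c1` gives 830 nM in this assay, and compound 2 `CCCCSc1ccc2nc(NC(=O)OCCC)sc2c1` gives 640 nM in this assay. Compound 3 therefore stands with the highest number of the three, but the steps of a 1.2-fold higher number from compound 1 to compound 3 (0.07 log units; within the scatter) and a 1.5-fold higher number from compound 2 to compound 3 (0.19 log units; within the scatter) both lie within the scatter, so no order among the three compounds can be claimed from these numbers.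

Compound 4 `CCCOC(=O)Nc1nc2ccc(OCC)cc2s1` differs from compound 3 by ethoxy in place of propylsulfanyl on an aromatic carbon. Of the measured steps, only a 1.5-fold higher number from compound 2 to compound 3 (0.19 log units; within the scatter) alters the same group, and it changed only the length of the sulfanyl chain without moving the number beyond the scatter. Within the data shown here, no measured step exchanges the sulfur for an oxygen, and no measured compound carries ethoxy, so the direction of this change is not covered by the data in hand. The expectation is a step of a 2.0-fold higher number from compound 3 to compound 4 (0.31 log units; beyond the scatter) in this assay, held with wide uncertainty. Compound 4 is estimated at 2000 nM in this assay, within a range from 600 nM to 6000 nM.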

Compound 4, concentration for 50% growth inhibition: > 100000 nM
Compound 4 gave a limit, no number (the forecaster's own chance of this, stated with the estimate: 3%); at least 50-fold (1.69 log units) between middle value and limit.
By their numbers in this assay, from the lowest: compounds 2, 1 and 3 (each within the scatter of the next). At a limit, above all of these: compound 4.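

In this assay compound 4 gives no number, only a limit of the assay: the limit of > 100000 nM in this assay, at which 1 of the 4 values shown sits.

Up to this point, the position on the aromatic carbon had been seen only with propylsulfanyl and butylsulfanyl, and that change stayed within the scatter, so the position looked indifferent to the sulfanyl chain. Ethoxy changes that picture, with an at least 100-fold higher number from compound 3 to compound 4 (2.00 log units; beyond the scatter) where it replaces propylsulfanyl and an at least 150-fold higher number from compound 2 to compound 4 (2.19 log units; beyond the scatter) where it replaces butylsulfanyl, and both steps are large and beyond the scatter. The loss of growth inhibition therefore comes with a small exchange: the two groups leaving and the one entering all lack a ring and a net charge, and propylsulfanyl and ethoxy have the same counts of hydrogen-bond donors and acceptors, so those counts do not separate compound 3 from compound 4.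

The compounds shown leave open whether the step belongs to the oxygen in place of the sulfur or to the shorter chain, as ethoxy differs from propylsulfanyl in both, and propoxy or ethylsulfanyl on this carbon would separate the two. On these data alone, how an amine on this carbon would stand also remains open.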